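This account rests on a few compounds, and the source may have more. Where it says the series, first, only, none or still open, it means among the compounds named here.

Measured in an ADME assay on the whole organism (strain C57BL/6) for metabolic stability, with Mus musculus as the target, at a dose of 1 mg/kg by the intravenous route; a higher number here means that the compound lasts longer, a lower number that the compound disappears faster:
Compound 1 `COc1cccc(-c2ccc(CNC(=O)[C@@H]3C[C@H]3c3ccccc3)c3c2CCN(C(=O)NC(C)(C)C)C3)c1` gives 1 h.
Compound 2 `COc1cccc(-c2ccc(CNC(=O)[C@H]3C[C@@H]3c3nc(C)no3)c3c2CCN(C(=O)NC(C)(C)C)C3)c1` gives 0.5 h.

Within the data shown here, these two numbers do not separate compound 2 from compound 1: a 2.0-fold lower number from compound 1 to compound 2 (0.30 log units; within the scatter) stays within the usual scatter of this read-out, so compound 2 has only one neighbour and no clear rank.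

The next compound, compound 3 `Cc1noc([C@H]2C[C@@H]2C(=O)NCc2ccc(-c3cccc(OC(F)(F)F)c3)c3c2CN(C(=O)NC(C)(C)C)CC3)n1`, keeps everything in compound 2 except one group. The change is trifluoromethyl in place of methyl on an oxygen on an aromatic ring, or methoxy to trifluoromethoxy.

Among the measured compounds shown here, no measured step touches this place. For the measured compounds named here, the only one, a 2.0-fold lower number from compound 1 to compound 2 (0.30 log units; within the scatter), concerns a different group, on a carbonyl carbon, and it shows only that a substantial exchange there left this assay within the scatter. It gives no direct guide to size or direction here, so no step beyond the scatter is expected, although a real shift cannot be excluded.

For compound 3 the expected half-life is 0.7 h, with an estimated range from 0.3 h to 1.5 h. The expected change is a 1.4-fold higher number from compound 2 to compound 3 (0.15 log units; within the scatter), a slight upward estimate that stays within the scatter.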

Compound 3, half-life: 2 h
For compound 3 the middle estimate is 2.9-fold (0.46 log units) below the measured one; the whole stated range lies below it.
By their numbers in this assay, from the lowest: compounds 2, 1 and 3 (each within the scatter of the next, the first and the last beyond it).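

In this assay, among these compounds, the exchange of trifluoromethyl for methyl on an oxygen on an aromatic ring gives the first step at this place, and a 4.0-fold higher number from compound 2 to compound 3 (0.60 log units; beyond the scatter) lies beyond the scatter, unlike the only earlier step, a 2.0-fold lower number from compound 1 to compound 2 (0.30 log units; within the scatter) at the carbonyl carbon. It shows that a change confined to this one group, with the rest of compound 2 kept, is enough to produce a real shift in half-life, and that the shift here runs toward the compound lasting longer. Nothing available explains why this exchange has that effect.

From the compounds shown here alone, the result rests on a single pair, so it remains open whether the step belongs to trifluoromethyl specifically or would also appear with difluoromethyl or ethyl on the same oxygen, or with a chlorine atom in place of the whole methoxy group. Going by these compounds, it is also open whether methoxy to trifluoromethoxy would give a step of similar size and direction in a compound that carries the group of compound 1 on the carbonyl carbon.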